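A few compounds are considered here, and "the series" means these few. Any claim that something is new, unique, unknown or untested is made for them only; others in the source may bear on it.

Compound 1 `Oc1ccc(-c2cc(-c3ccccn3)nc(-c3ccccc3Cl)c2)cc1` is reported as "not determined" (no result reported) in a functional assay on T47D cells (Homo sapiens) for cytotoxicity, read by CCK-8 assay and cell counting, with a stated time of 2 days (on this read-out lower numbers stand for stronger inhibition and higher numbers for weaker inhibition), so nothing can be said of where it stands on a number; the picture comes only from its neighbours. Compound 2 `Oc1ccc(-c2cc(-c3ccc(Cl)cc3)nc(-c3cccnc3)c2)cc1` gives 29300 nM in this assay. Compound 3 `Oc1ccc(-c2cc(-c3cccc(Cl)c3)nc(-c3ccccn3)c2)cc1` gives 27900 nM in this assay. These two values sit close to one another, and both point to weak inhibition for this family of 4-hydroxyphenyl bearing compounds.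

Compound 4 `Oc1ccc(-c2cc(-c3ccsc3)nc(-c3ccccc3Cl)c2)cc1` differs from compound 1 by a single exchange: thiophen-3-yl in place of pyridin-2-yl on an aromatic carbon. Within the data shown here, no measured pair in this set traces that exchange, so the size of the step can only be guessed. Given that the two measured relatives, compound 2 and compound 3, both lie far up the scale, the expectation is that compound 4 stays in the same weak region, with no step beyond the scatter in either direction that the data can support. Compound 4 is therefore estimated at 28000 nM in this assay, within a range from 9000 nM to 90000 nM.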

Compound 4, half-maximal inhibitory concentration: 6110 nM
Compound 4: the middle estimate sits 4.6-fold (0.66 log units) above what was measured, and the stated range ends above it.
By their numbers in this assay, from the lowest: compound 4; then compounds 3 and 2 (each within the scatter of the next).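

Among these compounds, compound 1 carries no number in this assay, so no step to compound 4 can be read from the exchange of pyridin-2-yl for thiophen-3-yl. As far as these compounds go, what that exchange itself does to the read-out stays open. Nothing given here bears on the result of compound 4.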